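The source may hold more compounds than are shown below. What is called first, only, known or untested is meant among the compounds shown, and "the series" means these compounds.

Measured so far in an assay on isolated protein for binding affinity to 5-hydroxytryptamine receptor 4 (Homo sapiens); a higher number here means a weaker inhibitor, a lower number a stronger inhibitor:
compound 1 `c1ccc(-c2n[nH]cc2N2CCNCC2)cc1` gives > 10000 nM, a limit of the assay.
compound 2 `Clc1cccc(-c2n[nH]cc2N2CCNCC2)c1` gives > 10000 nM, likewise only a limit.

Compound 2 therefore stands at the limit, not at a number, in this assay; both values shown sit there (the limit of > 10000 nM in this assay, at which 2 of the 2 values shown sit). The step that the two limits leave unreadable from compound 1 to compound 2 is left unreadable by the two limits. Compound 3 `Fc1cccc(-c2n[nH]cc2N2CCNCC2)c1` carries fluoro in place of chloro on an aromatic carbon. Within the data shown here, the only measured step on this series is the unreadable one, so no direction or size can be taken from it. Compound 3 is expected to remain at the limit as well, with an estimated 20000 nM in a range from 6000 nM to 100000 nM. The implied step that the limit leaves unreadable from compound 2 to compound 3 is expected to be no more than scatter.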

Compound 3, inhibition constant: > 10000 nM
Compound 3 was reported as a limit; the forecaster's own chance of this, stated with the estimate: 85%; the middle value is on the limit's open side.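

Among these compounds, no step among compound 1, compound 2 and compound 3 can be read in this assay, as each value is only a limit: the limit of > 10000 nM in this assay, at which 3 of the 3 values shown sit. The compounds shown leave open whether any change on the shared core gives a readable value in this assay.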